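Changing the ring group on the carbonyl of compound 2

The compounds below may be only part of what the source reports. "The series", "measured", "known", "first", "only" and "open" are said of these compounds alone.

In a functional assay on A2780 cells (Homo sapiens) for inhibition, read by sulforhodamine B assay, with a stated time of 72 h (a higher number here means a weaker inhibitor, a lower number a stronger inhibitor), compound 2 `O=C(NCc1ccc(S(=O)(=O)c2cccc(C(F)(F)F)c2)cc1)c1cc2cnccc2[nH]1` gives 3 nM, the lowest number of the three, while compound 1 `O=C(NCc1ccc(S(=O)(=O)c2ccccc2C(F)(F)F)cc1)c1cc2cnccc2[nH]1` gives 25 nM and compound 3 `O=C(NCc1ccc(S(=O)(=O)c2ccccc2)cc1)c1cc2cnccc2[nH]1` gives 18 nM. Compound 4 `O=C(NCc1ccc(S(=O)(=O)c2cccc(C(F)(F)F)c2)cc1)c1ccc2nccn2c1` differs from compound 2 only in the ring group on the carbonyl carbon: a group of 9 heavy atoms (7 carbon, 2 nitrogen; one five-membered aromatic ring with 2 hetero atoms, one six-membered aromatic ring with 1 hetero atom) in place of a group of 9 heavy atoms (7 carbon, 2 nitrogen; one five-membered aromatic ring with 1 hetero atom, one six-membered aromatic ring with 1 hetero atom), on a carbonyl carbon. The measured steps instead change the group on the sulfonyl sulfur, such as an 8.3-fold lower number from compound 1 to compound 2 (0.92 log units; beyond the scatter) and a 6.0-fold higher number from compound 2 to compound 3 (0.78 log units; beyond the scatter). None tests this swap directly, but both show that single changes can move the number modestly, and both moves away from compound 2 go upward. A small upward move is therefore expected, estimated as a 2.0-fold higher number from compound 2 to compound 4 (0.30 log units; within the scatter). Compound 4 is estimated at 6 nM, with an expected range from 1.5 nM to 25 nM.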

Compound 4, half-maximal inhibitory concentration: 2 nM
Beside the measured number, compound 4's estimate is 3.0-fold (0.48 log units) above it, within the range that was stated.
By their numbers in this assay, from the lowest: compounds 4 and 2 (each within the scatter of the next); then compounds 3 and 1 (each within the scatter of the next).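

Within the data shown here, the earlier compounds varied only the group on the sulfonyl sulfur, so this is the first view of the ring group on the carbonyl carbon. In this assay the swap gives a 1.5-fold lower number from compound 2 to compound 4 (0.18 log units; within the scatter), so the two numbers cannot be told apart, although the entering group has 0 hydrogen-bond donors where the leaving group has 1. Nothing shown gives a reason for this result.

From the compounds shown here alone, it remains open whether the same swap behaves alike on compound 1 or compound 3. Going by these compounds, the effect of an amine or a carboxylic acid on the new ring group also remains open.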